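A few compounds are considered here, and "the series" means these few. Any claim that something is new, unique, unknown or untested is made for them only; others in the source may bear on it.

Measured compounds:
compound 1 `CN1CCC(c2c[nH]c3ccc(NC(=O)C4CC4)nc23)CC1` with 77% in a functional assay for activation of 5-hydroxytryptamine receptor 1F (Homo sapiens), read by GTPgammaS binding; on this read-out lower numbers stand for smaller maximal responses and higher numbers for larger maximal responses
compound 2 `CN1CCC(c2c[nH]c3ccc(NC(=O)c4cccs4)nc23)CC1` with 61% in this assay

Compound 2 holds the lower of the two numbers measured in this assay; its nearest neighbour is compound 1, whose value stands higher by a gap that exceeds the scatter. Among the measured compounds shown here, the one step recorded so far, a number 16 percentage points lower from compound 1 to compound 2 (beyond the scatter), came with thiophen-2-yl in place of cyclopropyl on a carbonyl carbon.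

Compound 3 `CN1CCC(c2c[nH]c3ccc(NC(=O)c4ccncc4)nc23)CC1` has not yet been measured. It differs from compound 2 as follows: pyridin-4-yl in place of thiophen-2-yl on a carbonyl carbon.

The recorded step swaps a saturated ring for an aromatic one, whereas the step to compound 3 exchanges one aromatic ring for another of similar size. That earlier step therefore bears on the new one only loosely, showing that changes at this carbonyl carbon can shift the maximal response by a modest amount. For the measured compounds named here, no step between two aromatic rings at this position is available. The expectation for compound 3 in this assay is consequently a step of a number 4 percentage points higher from compound 2 to compound 3 (within the scatter), small and probably within the scatter, with no clear direction. Compound 3 is estimated at 65%, within a range from 45% to 85%.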

Compound 3, largest response reached (Emax), in percent of the reference or control that the assay uses: 97%
Compound 3: middle estimate off by 32 percentage points, on the low side, and the stated range ends below it.
By their numbers in this assay, from the lowest: compound 2; then compound 1; then compound 3.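

In this assay, the exchange of one aromatic ring for another on the carbonyl carbon proved far from neutral: pyridin-4-yl in place of thiophen-2-yl gave a number 36 percentage points higher from compound 2 to compound 3 (beyond the scatter), a step larger than any seen before. The two aromatic groups also fall on opposite sides of cyclopropyl, since a number 16 percentage points lower from compound 1 to compound 2 (beyond the scatter) contrasts with a number 20 percentage points higher from compound 1 to compound 3 (beyond the scatter), so in these three compounds an aromatic ring on this carbonyl carbon does not by itself set the direction of the change, and compound 3 stands beyond the scatter from both of the others. No measurement is available that would explain why the pyridin-4-yl compound reaches the larger maximal response.

The step to compound 3 changes the ring size and replaces sulfur with nitrogen at once, so the compounds shown cannot separate the two changes, and a phenyl group or a pyridin-3-yl group on the same carbonyl carbon would bear directly on that question. As far as these compounds go, it also remains open whether an amine or a longer chain on this carbonyl carbon would keep a maximal response of this size.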